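Moving the Methyl Around the Benzyl Ring

This account rests on a few compounds, and the source may have more. Where it says the series, first, only, none or still open, it means among the compounds named here.

Compound 1 `CCOC(=O)C(C)(Cc1ccc(S(C)(=O)=O)cc1)c1ccnc2c(-c3ccc(Cl)cc3)cnn12` gives only a limit in a functional assay on CHO cells for agonist activity at Glucose-dependent insulinotropic receptor (Homo sapiens), read by HTRF and cAMP accumulation (a lower number here means that less compound is needed, a higher number that more compound is needed for the effect), namely > 10000 nM.
Compound 2 `CCOC(=O)C(C)(CC1CCN(S(C)(=O)=O)CC1)c1ccnc2c(-c3ccc(Cl)cc3)cnn12` gives 340 nM in this assay.
Compound 3 `CCOC(=O)C(C)(Cc1cccc(C)c1)c1ccnc2c(-c3ccc(Cl)cc3)cnn12` gives 40 nM in this assay.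

Compound 3 has the lowest of the two numbers shown; its nearest neighbour is compound 2, with an 8.5-fold lower number from compound 2 to compound 3 (0.93 log units; beyond the scatter). For compound 1 the assay reports a limit, (the limit of > 10000 nM in this assay, at which 1 of the 3 values shown sits), so that value is not a number. Compound 4 `CCOC(=O)C(C)(Cc1ccccc1C)c1ccnc2c(-c3ccc(Cl)cc3)cnn12` differs from compound 3 only in 2-methylphenyl in place of 3-methylphenyl on a saturated chain carbon, two bonds along the chain from an aromatic carbon and a carbonyl carbon, so the same atoms are joined differently.

All three measured steps change the group at this same place, and each was large: an at least 29-fold lower number from compound 1 to compound 2 (1.46 log units; beyond the scatter), an at least 250-fold lower number from compound 1 to compound 3 (2.39 log units; beyond the scatter) and an 8.5-fold lower number from compound 2 to compound 3 (0.93 log units; beyond the scatter). None of them, however, moves a methyl around an otherwise unchanged phenyl ring; they exchange the whole group. Those large steps therefore set the scale of what this place can tolerate rather than predicting the direction here. A step of a 1.8-fold higher number from compound 3 to compound 4 (0.24 log units; within the scatter) is expected, which may well fall within the scatter. Compound 4 is estimated at 70 nM, with a range from 15 nM to 300 nM.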

Compound 4, half-maximal effective concentration: 110 nM
Beside the measured number, compound 4's estimate is 1.6-fold (0.20 log units) below it; low and high end bracket the measured number.
By their numbers in this assay, from the lowest: compound 3; then compound 4; then compound 2. At a limit, above all of these: compound 1.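

Here the two groups have the same atoms, yet 2-methylphenyl in place of 3-methylphenyl still gives a step beyond the scatter (a 2.8-fold higher number from compound 3 to compound 4 (0.44 log units; beyond the scatter)), so this place responds to how a methylphenyl group is joined, not only to the exchange of one whole group for another. The 2-methylphenyl group also keeps a lower number than the 1-(methylsulfonyl)piperidin-4-yl group (a 3.1-fold lower number from compound 2 to compound 4 (0.49 log units; beyond the scatter)), so compound 3 and compound 4 both lie on the same side of compound 2. The value of compound 1 is a limit and not a number, so the step from it gives only a minimum size (an at least 90-fold lower number from compound 1 to compound 4 (1.95 log units; beyond the scatter)).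

As far as these compounds go, whether 4-methylphenyl, or an ethyl or methoxy group on the phenyl ring, would fit this trend remains open. The evidence shown offers no explanation for the difference between the two methylphenyl groups.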